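One aryl exchange on an amide-type nitrogen

The source may hold more compounds than are shown below. What is called first, only, known or untested is meant among the compounds shown, and "the series" means these compounds.

In a functional assay on A549 cells (Homo sapiens) for cytotoxicity, read by MTT assay, with a stated time of 72 h (on this read-out lower numbers stand for stronger inhibition and higher numbers for weaker inhibition), three compounds sharing one core have been measured. Compound 2 `O=C(CN1CCN(c2nnc(Cc3ccccc3)c3ccccc23)CC1)Nc1ccc(F)c(C(F)(F)F)c1` gives 2480 nM, the lowest of the three numbers. Compound 3 `O=C(CN1CCN(c2nnc(Cc3ccncc3)c3ccccc23)CC1)Nc1ccc(F)c(C(F)(F)F)c1` gives 16000 nM, and compound 1 `COc1ccc(NC(=O)CN2CCN(c3nnc(Cc4ccncc4)c4ccccc34)CC2)cc1OC` gives 26500 nM. Compound 4 `COc1ccc(NC(=O)CN2CCN(c3nnc(Cc4ccccc4)c4ccccc34)CC2)cc1OC` has not yet been measured. It differs from compound 2 by 3,4-dimethoxyphenyl in place of 4-fluoro-3-(trifluoromethyl)phenyl on an amide-type nitrogen.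

Going by the values given here, two measured steps bear on this change. The same two groups are exchanged, in the opposite direction, among the compounds carrying pyridin-4-yl: a 1.7-fold lower number from compound 1 to compound 3 (0.22 log units; within the scatter). Read in reverse, that step hints at a slightly higher number for compound 4 than for compound 2, but no more than a hint. The other step is a 6.5-fold higher number from compound 2 to compound 3 (0.81 log units; beyond the scatter), for pyridin-4-yl in place of phenyl on a saturated chain carbon bound to an aromatic carbon. Compound 4 carries phenyl where compound 1 carries pyridin-4-yl, so if that step holds here, compound 4 should lie well under compound 1 and close to compound 2. Both routes lead to a similar expectation: a small move toward a higher number, not beyond the scatter. The estimate corresponds to an expected 1.6-fold higher number from compound 2 to compound 4 (0.21 log units; within the scatter). Compound 4 is estimated at 4000 nM, with an expected range of 1700 nM to 9500 nM.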

Compound 4, half-maximal inhibitory concentration: "not active" (no number reported)
Compound 4 has no reported number here; there is nothing to compare the estimate with.
By their numbers in this assay, from the lowest: compound 2; then compounds 3 and 1 (each within the scatter of the next).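

In this assay, going by these compounds alone, compound 4 is reported as not active, without a number, so no step from compound 2 or compound 1 to compound 4 can be read. The compounds shown leave open how far 3,4-dimethoxyphenyl in place of 4-fluoro-3-(trifluoromethyl)phenyl moves the number among compounds carrying phenyl. Nothing shown accounts for this report on compound 4.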